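This account rests on a few compounds, and the source may have more. Where it says the series, first, only, none or still open, it means among the compounds named here.

Working notes on a short series in a functional assay on cells (Cancer cell lines, Homo sapiens) for cytotoxicity, with a stated time of 48 h; a higher number here means a weaker inhibitor of growth, a lower number a stronger inhibitor of growth. Compound 1 `COc1cc2c(/C=C3/C(=O)Nc4ccc(O)cc43)c(Cl)n(Cc3cc(OC)c(OC)c(OC)c3)c2cc1C` gives 2040 nM in this assay; compound 2 `COc1ccc2c(c1)/C(=C\c1c(OC)n(-c3ccccc3)c3ccccc13)C(=O)N2` gives 980 nM, and compound 3 `O=C1Nc2ccc(Cl)cc2/C1=C\c1c(Cl)n(CCCc2ccccc2)c2ccccc12` gives 2820 nM. Compound 1 thus holds the second highest of the three numbers: against compound 3 the gap lies within the scatter, while against compound 2, whose number is lower, it lies beyond it. Compound 4 `COc1cc2c(/C=C3/C(=O)Nc4cccc(Cl)c43)c(Cl)n(Cc3cc(OC)c(OC)c(OC)c3)c2cc1C` differs from compound 1 in one place: a group of 12 heavy atoms (9 carbon, 1 nitrogen, 1 oxygen, 1 chlorine; one five-membered non-aromatic ring with 1 hetero atom, one six-membered aromatic ring of carbon only) in place of a group of 12 heavy atoms (9 carbon, 1 nitrogen, 2 oxygen; one five-membered non-aromatic ring with 1 hetero atom, one six-membered aromatic ring of carbon only), on an aromatic carbon. Going by the values given here, no step between measured compounds covers this change, so the expectation rests on the spread of the three numbers alone. The expected step is a 1.3-fold higher number from compound 1 to compound 4 (0.11 log units; within the scatter), small and probably not beyond the scatter, if anything toward a higher number. Compound 4 is estimated at 2600 nM, with a range from 1000 nM to 6500 nM.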

Compound 4, concentration for 50% growth inhibition: 3020 nM
The estimate for compound 4 lay 1.2-fold (0.07 log units) below the measured number, and the stated range covers the measured number.
By their numbers in this assay, from the lowest: compound 2; then compounds 1, 3 and 4 (each within the scatter of the next).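

In this assay, this aromatic carbon now has its first step, a 1.5-fold higher number from compound 1 to compound 4 (0.17 log units; within the scatter): the group of 12 heavy atoms with 2 oxygen and the one with 1 oxygen and 1 chlorine, which share the same ring make-up, are not separated by this read-out. No measurement here offers an explanation for this result. Going by these compounds, whether a group carrying an amine or a carboxylic acid in place of the chlorine would give a step beyond the scatter remains open. Also open, on these data alone, is whether the same exchange would stay as small on the core of compound 2.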